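Chain extension at the thioether of the shared core

The source may hold more compounds than are shown below. What is called first, only, known or untested is meant among the compounds shown, and "the series" means these compounds.

Compound 3 `CCCSc1n[nH]c(-n2[se]c3ccccc3c2=O)n1` gives 31800 nM in an ADME assay on L929 cells (Mus musculus) for antiproliferative activity, read by CCK-8 assay, with a stated time of 48 h; on this read-out lower numbers stand for stronger inhibition and higher numbers for weaker inhibition. Among the three measured members it holds the second highest number: compound 1 `CCCCCCSc1n[nH]c(-n2[se]c3ccccc3c2=O)n1` gives 39300 nM, a value within the scatter of compound 3, while compound 2 `Cc1ccccc1CSc1n[nH]c(-n2[se]c3ccccc3c2=O)n1` gives 15600 nM, so that a 2.0-fold higher number from compound 2 to compound 3 (0.31 log units; beyond the scatter) and a 2.5-fold lower number from compound 1 to compound 2 (0.40 log units; beyond the scatter) are the only steps beyond the scatter in the set.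

Compound 4 `CCCCCSc1n[nH]c(-n2[se]c3ccccc3c2=O)n1` is not yet measured. It differs from compound 3 as follows: ethyl in place of hydrogen on a saturated chain carbon, three bonds along the chain from a sulfur.

The step most directly comparable is a 1.2-fold lower number from compound 1 to compound 3 (0.09 log units; within the scatter), which is the same kind of change, run in the opposite direction and with a longer group at the same place. That step stayed within the scatter. The steps of a 2.5-fold lower number from compound 1 to compound 2 (0.40 log units; beyond the scatter) and a 2.0-fold higher number from compound 2 to compound 3 (0.31 log units; beyond the scatter) involve a change of group class rather than a change of chain length at this place, and do not bear on the present step.

Accordingly, no step beyond the scatter is expected: a 1.1-fold higher number from compound 3 to compound 4 (0.04 log units; within the scatter) is the estimated change. Compound 4 is expected to give 35000 nM in this assay, with a plausible range from 17000 nM to 70000 nM.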

Compound 4, half-maximal inhibitory concentration: 33500 nM
Compound 4: middle estimate off by 1.0-fold (0.02 log units), on the high side, and the stated range covers the measured number.
By their numbers in this assay, from the lowest: compound 2; then compounds 3, 4 and 1 (each within the scatter of the next).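

In this assay, ethyl in place of hydrogen on a saturated chain carbon, three bonds along the chain from a sulfur, gives a 1.1-fold higher number from compound 3 to compound 4 (0.02 log units; within the scatter) and hydrogen in place of methyl on a saturated chain carbon, five bonds along the chain from a sulfur, gives a 1.2-fold lower number from compound 1 to compound 4 (0.07 log units; within the scatter); with compound 4 in place, all three unbranched chains on the sulfur of the shared core lie within the scatter of one another, so chain length at this place shows no readable effect across compounds 1, 3 and 4. Among the compounds shown here, the remaining new step is a 2.1-fold higher number from compound 2 to compound 4 (0.33 log units; beyond the scatter), which makes compound 2 the only member with a step beyond the scatter to every other compound, and the only one carrying a ring on that chain carbon. No accompanying data account for either the flat chain series or the separate position of compound 2.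

From the compounds shown here alone, it remains open what an amine or a carboxylic acid at the end of the chain would give at this place. Going by these compounds, it also remains open whether phenyl in place of 2-methylphenyl would hold the number of compound 2 15600 nM or fall back among the chain compounds.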